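The source may hold more compounds than are shown below. What is called first, only, known or untested is meant among the compounds shown, and "the series" means these compounds.

Measured in a functional assay on HeLa cells (Homo sapiens) for cytotoxicity, read by ELISA, with a stated time of 2 days; on this read-out lower numbers stand for stronger inhibition and higher numbers for weaker inhibition:
Compound 1 `Oc1cccc(-c2cc(-c3ccccc3)cc(-c3ccsc3)n2)c1`: 13800 nM
Compound 2 `Oc1ccc(-c2cc(-c3ccccc3)cc(-c3cccs3)n2)cc1`: 1700 nM

Of these two compounds, compound 2 has the lower number, and the gap to compound 1 at 13800 nM lies beyond the scatter of this assay. Compound 3 `Oc1ccc(-c2cc(-c3ccccc3)cc(-c3ccsc3)n2)cc1` has not yet been measured. It differs from compound 2 by thiophen-3-yl in place of thiophen-2-yl on an aromatic carbon, next to the ring nitrogen (thiophen-3-yl in place of thiophen-2-yl on an aromatic carbon). Among the compounds with values here, no measured pair differs in one place only, so the data give no direct size for such a swap. A small move toward weaker inhibition is expected, a 1.5-fold higher number from compound 2 to compound 3 (0.17 log units; within the scatter), which would not lie beyond the scatter. For compound 3 the estimated value is 2500 nM, with an expected range from 800 nM to 8000 nM.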

Compound 3, half-maximal inhibitory concentration: 17300 nM
The estimate for compound 3 lay 6.9-fold (0.84 log units) below the measured number, and the stated range ends below it.
By their numbers in this assay, from the lowest: compound 2; then compounds 1 and 3 (each within the scatter of the next).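

In this assay the way the thiophene is attached on the aromatic carbon next to the ring nitrogen proves to matter: thiophen-3-yl in place of thiophen-2-yl gives a 10-fold higher number from compound 2 to compound 3 (1.01 log units; beyond the scatter) even though the two groups have the same atoms and the same counted features. With thiophen-3-yl in that place, 4-hydroxyphenyl in place of 3-hydroxyphenyl gives a 1.3-fold higher number from compound 1 to compound 3 (0.10 log units; within the scatter) and stays within the scatter, so these two hydroxyphenyl groups cannot be told apart in this setting. No evidence is available that bears on why the thiophene change has so large a step.

As far as these compounds go, whether the hydroxyl position would count for as little alongside thiophen-2-yl stays open. Also open, from the compounds shown here alone, is what an amine or a carboxylic acid in place of the hydroxyl, or a furan in place of the thiophene, would do.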